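Shifting the Fluoro Group on One Aromatic Ring

The source may report more compounds than this note shows. Statements on the series, on what has been measured and on what is new or still open speak of the compounds shown alone.

Compound 1 `O=C(/C=C/c1ccc2c(c1)B(O)OC2)c1ccc(OCc2ccccc2)cc1` and compound 2 `O=C(/C=C/c1ccc2c(c1)B(O)OC2)c1ccc(F)cc1` share one core and differ by a fluoro in place of benzyloxy on an aromatic carbon. In an ADME assay on L929 cells (Mus musculus) for cytotoxicity, read by resazurin assay, with a stated time of 72 h (a lower number here means a stronger inhibitor, a higher number a weaker inhibitor), compound 1 reaches only the limit of the assay, > 10 ug/mL. Compound 2 likewise reaches only the limit, > 10 ug/mL. The step that the two limits leave unreadable from compound 1 to compound 2 cannot be read, since both values sit at the limit of > 10 ug/mL in this assay, at which 2 of the 2 values shown sit. Compound 3 `O=C(/C=C/c1ccc2c(c1)B(O)OC2)c1cccc(F)c1` differs from compound 2 by 3-fluorophenyl in place of 4-fluorophenyl on a carbonyl carbon. No readable step bears on this change. Compound 3 is therefore expected to sit near the same limit, with a step that the limit leaves unreadable from compound 2 to compound 3 expected to stay within the scatter. The estimate for compound 3 is 15 ug/mL, in the range 7 ug/mL to 40 ug/mL.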

Compound 3, half-maximal inhibitory concentration: > 10 ug/mL
Compound 3: a limit, no number; the forecaster's own chance of this, stated with the estimate: 80%; the middle value is on the limit's open side.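

Compound 3 also gives only a limit of the assay, so the step from compound 2 to compound 3 cannot be read: the limit of > 10 ug/mL in this assay, at which 3 of the 3 values shown sit.

On these data alone, how moving the fluoro group affects cytotoxicity, and where these compounds truly lie beyond that limit, remains open.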